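This account rests on a few compounds, and the source may have more. Where it says the series, first, only, none or still open, it means among the compounds named here.

Measured so far:
compound 1 `COc1cc(-c2nn(-c3cccc(NC(=O)c4cccc(C(F)(F)F)c4)c3)cc2-c2ccncc2)ccc1Cl`, 9270 nM
compound 2 `O=C(Nc1cccc(-n2cc(-c3ccncc3)c(-c3ccc(Cl)c(O)c3)n2)c1)Nc1ccc(Cl)c(Cl)c1`, 3570 nM

In a functional assay on NCI-H460 cells (Homo sapiens) for inhibition, read by sulforhodamine B assay, with a stated time of 48 h (a higher number here means a weaker inhibitor of growth, a lower number a stronger inhibitor of growth), compound 1 gives the higher of the two numbers; compound 2 gives the lower number, and the gap between them lies beyond the usual scatter. Compound 3 `COc1cc(-c2nn(-c3cccc(NC(=O)c4ccc(Cl)c(C(F)(F)F)c4)c3)cc2-c2ccncc2)ccc1Cl` is the next compound to measure. Relative to compound 1 the change is chloro in place of hydrogen on an aromatic carbon. Among the measured compounds shown here, no comparable step is measured, so the size of the effect is uncertain. A modest move toward a lower number, at most a little beyond the scatter, is expected for compound 3, as the step of a 1.9-fold lower number from compound 1 to compound 3 (0.27 log units; within the scatter). Compound 3 is estimated at 5000 nM, with a range from 1500 nM to 15000 nM.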

Compound 3, concentration for total growth inhibition: > 32500 nM
Compound 3: a limit, no number; the forecaster's own chance of this, stated with the estimate: 5%; middle value at least 6.5-fold (0.81 log units) away from the limit.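

In this assay compound 3 gives > 32500 nM, a limit of the assay and not a number. Chloro in place of hydrogen on this aromatic carbon, ortho to a trifluoromethyl group and para to a large group, gives an at least 3.5-fold higher number from compound 1 to compound 3 (0.54 log units; beyond the scatter), so in this one pair a single added atom at this position weakens growth inhibition beyond the scatter. From the compounds shown here alone, the full size of the step stays unknown, with only its lower bound readable.

Going by these compounds, whether the loss is specific to chloro remains open. A fluoro, methyl or amine at this carbon could separate the effect of chloro from that of any substitution there.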